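Chloro to (Trifluoromethyl)sulfanyl on the Urea Aryl Ring

This account rests on a few compounds, and the source may have more. Where it says the series, first, only, none or still open, it means among the compounds named here.

Three compounds sharing one core were measured in an ADME assay for permeability, using PAMPA, at pH 7.4; a lower number here means that the compound crosses the layer more slowly, a higher number that the compound crosses the layer faster. Compound 1 `Cc1cc(NC(=O)Nc2ccc(F)cc2)c2ccccc2n1` gives 801 10^-6 cm/s in this assay, compound 3 `Cc1cc(NC(=O)Nc2ccc(Cl)cc2)c2ccccc2n1` gives 537 10^-6 cm/s, and compound 2 `Cc1cc(NC(=O)Nc2ccc(N(C)C)cc2)c2ccccc2n1` gives 2 10^-6 cm/s. Compound 3 thus stands second highest of the three: a 1.5-fold lower number from compound 1 to compound 3 (0.17 log units; within the scatter), while a 270-fold higher number from compound 2 to compound 3 (2.43 log units; beyond the scatter). Compound 4 `Cc1cc(NC(=O)Nc2ccc(SC(F)(F)F)cc2)c2ccccc2n1` differs from compound 3 by (trifluoromethyl)sulfanyl in place of chloro on an aromatic carbon. Among the measured compounds shown here, no measured step exchanges these two groups. For the measured compounds named here, the one step that does not involve dimethylamino, a 1.5-fold lower number from compound 1 to compound 3 (0.17 log units; within the scatter), was small, whereas the large steps of a 400-fold lower number from compound 1 to compound 2 (2.60 log units; beyond the scatter) and a 270-fold higher number from compound 2 to compound 3 (2.43 log units; beyond the scatter) both involve dimethylamino, which compound 4 does not carry. A step of a 1.1-fold lower number from compound 3 to compound 4 (0.03 log units; within the scatter) is therefore expected, within the scatter of compound 3. Compound 4 is estimated at 500 10^-6 cm/s, in a range from 220 10^-6 cm/s to 1000 10^-6 cm/s.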

Compound 4, apparent permeability: 206 10^-6 cm/s
Beside the measured number, compound 4's estimate is 2.4-fold (0.39 log units) above it; measured number below the stated range.
By their numbers in this assay, from the lowest: compound 2; then compound 4; then compounds 3 and 1 (each within the scatter of the next).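

In this assay the swap between the two halogens stayed within the scatter, but (trifluoromethyl)sulfanyl gives steps beyond it from both halogen compounds (a 2.6-fold lower number from compound 3 to compound 4 (0.42 log units; beyond the scatter); a 3.9-fold lower number from compound 1 to compound 4 (0.59 log units; beyond the scatter)). This place therefore responds to a group other than dimethylamino, although compound 4 remains far from compound 2 (a 100-fold higher number from compound 2 to compound 4 (2.01 log units; beyond the scatter)). Nothing measured here accounts for these differences. Still open, on these data alone, is where other groups at this place would fall, such as a nitrile, a carboxylic acid or a primary amine, relative to compound 2 and the halogen compounds.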